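Turning One Double Bond from E to Z

The compounds below may be only part of what the source reports. "The series", "measured", "known", "first", "only" and "open" are said of these compounds alone.

In a functional assay on M12 cells (Homo sapiens) for antiproliferative activity, read by WST assay, with a stated time of 72 h (a higher number here means that more compound is needed for the effect, a lower number that less compound is needed), compound 3 `CCCCCCCC/C=C/c1c(C)c(/C=C/CCCCCCCC)c2[n+](c1C)CCC2` gives 2.2 uM. Compound 1 `CCCCCCCCCCc1c(C)c(CCCCCCCCCC)c2[n+](c1C)CCC2` gives 1.9 uM, which lies within the usual scatter of the value for compound 3. For the measured compounds named here, compound 2 `CCCCCCCCCCc1c(C)cc(C)[n+]2c1CCC2` gives 0.9 uM, the lowest number so far and clearly apart from the value for compound 3.

The next compound to be tested is compound 4 `CCCCCCCC/C=C\c1c(C)c(/C=C/CCCCCCCC)c2[n+](c1C)CCC2`, and its relation to compound 3 is a subtle one: the two compounds have the same atoms and bonds and differ only in configuration as drawn: 1 of 2 stereo elements differ; a double bond is drawn E in compound 3 and Z in compound 4.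

Going by the values given here, only one measured step is available as a guide: a 2.1-fold lower number from compound 1 to compound 2 (0.32 log units; beyond the scatter). That step is modest, and it replaces a whole decyl group with hydrogen, whereas nothing enters or leaves here. Among the compounds with values here, no measured pair tests a change of double bond configuration alone, so the evidence is indirect. From the compounds shown here alone, a small change, not clearly beyond the scatter, is therefore the expectation, and its direction stays open. The expected step is a 1.1-fold lower number from compound 3 to compound 4 (0.04 log units; within the scatter). The estimated value for compound 4 is 2 uM, with an expected range from 1 uM to 4 uM.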

Compound 4, concentration for half-maximal effect: 2.2 uM
Beside the measured number, compound 4's estimate is 1.1-fold (0.04 log units) below it; low and high end bracket the measured number.
By their numbers in this assay, from the lowest: compound 2; then compounds 1, 3 and 4 (each within the scatter of the next).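

In this assay, turning this double bond from E to Z gives no change at the digits printed from compound 3 to compound 4 (within the scatter). With the other double bond left E, the configuration of this one makes no measurable difference to the number in this cell assay. For the compounds shown here, the only earlier step, a 2.1-fold lower number from compound 1 to compound 2 (0.32 log units; beyond the scatter), replaced a whole decyl group with hydrogen and could say nothing about configuration, whereas this comparison isolates a single feature: the fact that compounds 3 and 4 differ only in the configuration as drawn.

Still open, from the compounds shown here alone, is whether the same holds when the other double bond is turned to Z, or when both are Z together. A longer chain in this place, or a chain ending in an amine or a carboxylic acid, would test whether the number responds to what the chain carries, something a change of configuration alone cannot reveal.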